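Swapping a ring substituent on a thiosemicarbazone series

The source may hold more compounds than are shown below. What is called first, only, known or untested is meant among the compounds shown, and "the series" means these compounds.

Measured compounds:
Compound 1, `Cc1cccc(/C(N)=N/NC(=S)N2CCCCC2)n1`, gives 36.6%.
Compound 2, `N/C(=N\NC(=S)N1CCOCC1)c1ccccn1`, gives 43.1%.
Compound 3, `N/C(=N\NC(=S)N1CCN(c2ccccn2)CC1)c1ccc(F)cn1`, gives 43%.

These three numbers all come from a functional assay on A-431 cells (Homo sapiens) for cytotoxicity, read by MTT assay, with a stated time of 72 h, tested at 3 uM; a lower number here means less inhibition of growth, a higher number more inhibition of growth at the concentration tested. On that scale compound 3 has the second highest of the three numbers, but its nearest neighbour, compound 2, lies only a hair above it, and even the furthest, compound 1, sits within the usual scatter, so the three compounds cannot be told apart by these readings. Going by the values given here, no two of the measured compounds differ in only one place, so no single-change step is available from them.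

Compound 4, `Cc1ccnc(/C(N)=N/NC(=S)N2CCN(c3ccccn3)CC2)c1`, is the next compound to be measured in this assay. It differs from compound 3 in one place: 4-methylpyridin-2-yl in place of 5-fluoropyridin-2-yl on a carbon with a double bond to nitrogen. The change exchanges one six-membered aromatic ring with one hetero atom for another of the same size, keeping the donor and acceptor count the same. Among the compounds with values here, with no measured step of this kind to lean on, and with all three neighbours clustered together, the expected step from compound 3 to compound 4, a number 3 percentage points lower from compound 3 to compound 4 (within the scatter), is none beyond the scatter. Compound 4 is therefore estimated at 40%, with a plausible range from 25% to 55%.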

Compound 4, percent growth inhibition at one concentration: 34.7%
Compound 4: the middle estimate sits 5.3 percentage points above what was measured, and the stated range covers the measured number.
By their numbers in this assay, from the lowest: compounds 4, 1, 3 and 2 (each within the scatter of the next).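

Going by these compounds alone, this is the first change in the set that can be read on its own. In this assay, putting 4-methylpyridin-2-yl in place of 5-fluoropyridin-2-yl on the carbon with a double bond to nitrogen gives a number 8.3 percentage points lower from compound 3 to compound 4 (within the scatter) and so does not separate the two compounds. At this place, then, a ring with a fluorine can be exchanged for a ring with a methyl group, with the substituent also sitting at a different ring position, without a reading that stands clear of the usual variation, although this single exchange alters both the substituent and its position, so neither can be judged alone. Nothing measured here on the properties of these groups bears on the step.

Still open, on these data alone, is whether a more different substituent on this ring, such as an amine, a carboxylic acid or a longer chain like butyl, would move the number beyond the scatter. Also open, as far as these compounds go, is whether the same exchange gives a similar step when the other end of the molecule carries a different group.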